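Series notes: the step from compound 3 to compound 4

The source may report more compounds than this note shows. Statements on the series, on what has been measured and on what is new or still open speak of the compounds shown alone.

Measured so far in an ADME assay on CHO-K1 cells (Cricetulus griseus) for cytotoxicity, read by MTT assay, with a stated time of 24 h; on this read-out higher numbers stand for weaker inhibition and lower numbers for stronger inhibition:
compound 1 `O=[N+]([O-])c1cc(Sc2nnnn2C2CCCCC2)cc([N+](=O)[O-])c1` — 153000 nM
compound 2 `O=[N+]([O-])c1cc(-c2nnn(Cc3ccccc3)n2)cc([N+](=O)[O-])c1` — 150000 nM
compound 3 `Cc1ccc(Cn2nnc(-c3cc([N+](=O)[O-])cc([N+](=O)[O-])c3)n2)cc1` — 200000 nM

Compound 3 stands with compound 1 and compound 2 inside the scatter; nothing separates the three numbers. For the measured compounds named here, the one measured step, a 1.3-fold higher number from compound 2 to compound 3 (0.12 log units; within the scatter), concerns methyl in place of hydrogen on an aromatic carbon and did not move the read-out. Compound 4 `O=[N+]([O-])c1cc(-c2nnn(Cc3cccc(Br)c3)n2)cc([N+](=O)[O-])c1` differs from compound 3 by 3-bromophenyl in place of 4-methylphenyl on a saturated chain carbon bound to an aromatic nitrogen. Going by the values given here, no measured step touches bromine, so only the within-scatter step from compound 2 to compound 3 offers any guide. Compound 4 is therefore expected to remain at the level of compound 3, with an estimated step of a 1.1-fold lower number from compound 3 to compound 4 (0.05 log units; within the scatter) in this assay. The estimate for compound 4 is 180000 nM, ranging from 90000 nM to 360000 nM.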

Compound 4, half-maximal inhibitory concentration: 29000 nM
Compound 4: the middle estimate sits 6.2-fold (0.79 log units) above what was measured, outside the stated range (below it).
By their numbers in this assay, from the lowest: compound 4; then compounds 2, 1 and 3 (each within the scatter of the next).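

In this assay, for the compounds shown here, adding a bromo group gives a 5.2-fold lower number from compound 2 to compound 4 (0.71 log units; beyond the scatter), the first step beyond the scatter. The change from 4-methylphenyl to 3-bromophenyl on a saturated chain carbon bound to an aromatic nitrogen gives a 6.9-fold lower number from compound 3 to compound 4 (0.84 log units; beyond the scatter), so this position can move the read-out, although methyl in place of hydrogen left it within the scatter. No evidence on the cause of these steps is available. From the compounds shown here alone, whether a chloro or an amine in place of the bromo would give a similar step remains open. Going by these compounds, whether the step carries over to the core of compound 1 also remains open.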